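The source may report more compounds than this note shows. Statements on the series, on what has been measured and on what is new or still open speak of the compounds shown alone.

- compound 1 `Cc1ccc(N(CC(C)C)S(=O)(=O)c2ccc3c(c2)C(=O)CC(C2CCOCC2)O3)c(C)c1` gives 4.28 in a physicochemical assay for lipophilicity, at pH 7.4; a higher number here means a more lipophilic compound, a lower number a more polar compound
- compound 2 `CC(C)CN(c1cc2ccccc2s1)S(=O)(=O)c1ccc2c(c1)C(=O)CC(C1CCOCC1)O2` gives 4.01 in this assay

Among the measured compounds shown here, compound 2 stands within the scatter of the only other compound measured so far, so the two numbers do not separate. The next compound is compound 3 `CC(C)CN(c1ccc(F)cc1F)S(=O)(=O)c1ccc2c(c1)C(=O)CC(C1CCOCC1)O2`, which carries 2,4-difluorophenyl in place of 1-benzothiophen-2-yl on a sulfonamide nitrogen with the rest unchanged. For the measured compounds named here, only one measured step falls at this same place, and it is small: a number 0.27 log units lower from compound 1 to compound 2 (within the scatter) on swapping the group there. With that single step as the guide, no step beyond the scatter is expected in this assay, though a slight fall is thought more likely than a rise. The expected step is a number 0.21 log units lower from compound 2 to compound 3 (within the scatter) on this thin evidence. For compound 3 the estimated value is 3.8, with an expected range from 3.45 to 4.15 for now.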

Compound 3, distribution coefficient: 3.62
The estimate for compound 3 lay 0.18 log units above the measured number; the measured number falls inside the stated range.
By their numbers in this assay, from the lowest: compound 3; then compounds 2 and 1 (each within the scatter of the next).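

At this place on the sulfonamide nitrogen, the choice of group can now be seen to move the number in this assay by more than the scatter, which the first pair did not show: 2,4-difluorophenyl gives both a step (a number 0.39 log units lower from compound 2 to compound 3 (beyond the scatter)) and a larger one (a number 0.66 log units lower from compound 1 to compound 3 (beyond the scatter)). Compound 3 therefore stands apart from compound 1 and compound 2, which remain within the scatter of each other, so 1-benzothiophen-2-yl and 2,4-dimethylphenyl still do not separate. No supporting measurement bears on why the number changes at this place.

Still open, going by these compounds, is whether the two fluorine atoms are needed for this step, which a plain phenyl or a single-fluorine phenyl group at this place would test. Also open, on these data alone, is whether an amine or a carboxylic acid carried on the group here would take the number lower than compound 3 does.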